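The source may report more compounds than this note shows. Statements on the series, on what has been measured and on what is new or still open speak of the compounds shown alone.

Measured so far:
Compound 1 `O=C1C(=O)N(CN2CCN(c3ccnc4cc(C(F)(F)F)ccc34)CC2)c2cc(Br)ccc21` gives 24800 nM in a functional assay on MDA-MB-468 cells (Homo sapiens) for cytotoxicity, read by sulforhodamine B assay, with a stated time of 48 h; a lower number here means a stronger inhibitor of growth, a higher number a weaker inhibitor of growth.
Compound 2 `O=C1C(=O)N(CN2CCN(c3ccnc4cc(C(F)(F)F)ccc34)CC2)c2ccccc21` gives 15300 nM in this assay.
Compound 3 `NC(=S)N/N=C1/C(=O)N(CN2CCN(c3ccnc4cc(C(F)(F)F)ccc34)CC2)c2cc(Br)ccc21` gives 39600 nM in this assay.

Compound 1 and compound 2 share one core and differ by hydrogen in place of bromo on an aromatic carbon; that change produced a 1.6-fold lower number from compound 1 to compound 2 (0.21 log units; within the scatter). Compound 3 carries a different core, and the difference between the two cores is not broken down here; its number is higher than that of compound 2 by a margin beyond the scatter, while its gap to compound 1 stays within the scatter.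

Compound 4 `NC(=S)N/N=C1/C(=O)N(CN2CCN(c3ccnc4cc(C(F)(F)F)ccc34)CC2)c2ccccc21` is related to compound 3 by hydrogen in place of bromo on an aromatic carbon, the same change as that from compound 1 to compound 2, at the same kind of position. On that basis compound 4 is expected to show a 1.6-fold lower number from compound 3 to compound 4 (0.20 log units; within the scatter), resting on the earlier step of a 1.6-fold lower number from compound 1 to compound 2 (0.21 log units; within the scatter) seen with compound 1 and compound 2. The estimate for compound 4 in this assay is 25000 nM, with a likely range from 10000 nM to 60000 nM.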

Compound 4, concentration for 50% growth inhibition: 10300 nM
Compound 4: the middle estimate sits 2.4-fold (0.39 log units) above what was measured, within the range that was stated.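

In this assay, hydrogen in place of bromo gave a 3.8-fold lower number from compound 3 to compound 4 (0.58 log units; beyond the scatter), a step that lies beyond the scatter, and the two cores do not separate on this change: the same change on two cores in this assay, a 1.6-fold lower number (0.21 log units; within the scatter) from compound 1 to compound 2 and a 3.8-fold lower number (0.58 log units; beyond the scatter) from compound 3 to compound 4, 2.4-fold (0.38 log units) apart, within the scatter of two such steps Within this series, then, the step measured on one core is a fair guide to the step on the other. Going by these compounds alone, it does not show that the two steps are equal in size, since only two pairs are available and the step on the core of compound 1 alone stays within the scatter.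

The compounds shown leave open what a group other than bromo would do on this aromatic carbon, such as chloro, methoxy or an amine. They also leave open whether the change would carry to a third core.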